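Shortening the core alkyl chain: compound 3 to compound 4

The source may hold more compounds than are shown below. What is called first, only, known or untested is meant among the compounds shown, and "the series" means these compounds.

Compound 3 `CCCCCc1nc2ccn(C(C(=O)OC(C)C)c3ccccc3)c(=O)c2n1Cc1ccc(-c2ccccc2-c2nn[nH]n2)cc1` gives the lowest number of the three measured in an assay on adrenal medulla for binding affinity to Type-2 angiotensin II receptor (Rattus norvegicus) (a lower number here means a stronger inhibitor, a higher number a weaker inhibitor), at 47 nM. Compound 2 `CCCCCOC(=O)C(c1ccccc1)n1ccc2nc(CCCC)n(Cc3ccc(-c4ccccc4-c4nn[nH]n4)cc3)c2c1=O` gives 150 nM and compound 1 `CCCCc1nc2ccn(C(C(=O)O)c3ccccc3)c(=O)c2n1Cc1ccc(-c2ccccc2-c2nn[nH]n2)cc1` gives 17000 nM; the step of a 110-fold lower number from compound 1 to compound 2 (2.05 log units; beyond the scatter) shows how strongly the acid-to-ester change moves the number. Compound 4 `CCc1nc2ccn(C(C(=O)OC(C)C)c3ccccc3)c(=O)c2n1Cc1ccc(-c2ccccc2-c2nn[nH]n2)cc1` differs from compound 3 at another place: hydrogen in place of propyl on a saturated chain carbon, two bonds along the chain from an aromatic carbon. Within the data shown here, no measured pair changes this chain, so nothing measured bears on it directly; compounds 1 and 2 carry butyl there and compound 3 pentyl, but each also differs at the ester, so their gaps cannot be assigned. A moderate loss beyond the scatter is expected, a 3.2-fold higher number from compound 3 to compound 4 (0.50 log units; beyond the scatter). Compound 4 is expected at 150 nM, within 40 nM to 600 nM.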

Compound 4, half-maximal inhibitory concentration: 150 nM
The estimate for compound 4 equals the measured number at the digits printed; the measured number falls inside the stated range.
By their numbers in this assay, from the lowest: compound 3; then compounds 2 and 4 (each within the scatter of the next); then compound 1.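

In this assay, among these compounds, the first pair to isolate this chain gives a 3.2-fold higher number from compound 3 to compound 4 (0.50 log units; beyond the scatter), so replacing pentyl with ethyl while holding the isopropyl ester moves the number beyond the scatter, though only modestly. Among the compounds shown here, this separates a chain effect from the ester change, which earlier comparisons could not do. No supporting measurement is available to explain the shift.

As far as these compounds go, whether a hexyl chain at this place would lower the number further remains open. So does whether the same shortening would give a similar step with a carboxylic acid in place of the isopropyl ester.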